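Rearranging Two Fluorines on the Sulfonamide Phenyl Group

The source may hold more compounds than are shown below. What is called first, only, known or untested is meant among the compounds shown, and "the series" means these compounds.

In a functional assay on cells (leukaemia cell line, Homo sapiens) for inhibition, read by sulforhodamine B assay, with a stated time of 48 h (a lower number here means a stronger inhibitor of growth, a higher number a weaker inhibitor of growth), compound 1 (`O=S(=O)(Nc1ccccc1Cl)c1ccc(-c2cnc(C3CC3)o2)cc1`) gives 429 nM and compound 2 (`O=S(=O)(Nc1ccc(Cl)c(F)c1)c1ccc(-c2cnc(C3CC3)o2)cc1`) gives 380 nM while compound 3 (`O=S(=O)(Nc1ccc(F)cc1F)c1ccc(-c2cnc(C3CC3)o2)cc1`) gives 356 nM so compound 3 stands level with both. Compound 4 (`O=S(=O)(Nc1cc(F)cc(F)c1)c1ccc(-c2cnc(C3CC3)o2)cc1`) has the same atoms, with 3,5-difluorophenyl in place of 2,4-difluorophenyl on a sulfonamide nitrogen. Three changes at that place bear on it, namely a 1.1-fold lower number from compound 1 to compound 2 (0.05 log units; within the scatter) and a 1.2-fold lower number from compound 1 to compound 3 (0.08 log units; within the scatter) and a 1.1-fold lower number from compound 2 to compound 3 (0.03 log units; within the scatter) and none leaves the scatter. For the measured compounds named here, no measured compound carries 3,5-difluorophenyl, yet no step beyond the scatter is expected in this assay and no direction can be called. The expected step is a 1.1-fold higher number from compound 3 to compound 4 (0.03 log units; within the scatter) as estimated here. For compound 4 the estimate is an expected 380 nM (range 190 nM to 760 nM).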

Compound 4, concentration for 50% growth inhibition: 2140 nM
Compound 4: middle estimate off by 5.6-fold (0.75 log units), on the low side; the measured number lies above the stated range.
By their numbers in this assay, from the lowest: compounds 3, 2 and 1 (each within the scatter of the next); then compound 4.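

In this assay, for the compounds shown here, the place on a sulfonamide nitrogen proves sensitive to how the two fluorines are arranged, which the earlier compounds, all within the scatter of one another, did not reveal: with the atoms unchanged, the step is a 6.0-fold higher number from compound 3 to compound 4 (0.78 log units; beyond the scatter) and the number is higher. The 3,5-difluorophenyl group also stands apart from the other two groups, with a 5.6-fold higher number from compound 2 to compound 4 (0.75 log units; beyond the scatter) and a 5.0-fold higher number from compound 1 to compound 4 (0.70 log units; beyond the scatter) as its remaining steps. Nothing measured here accounts for this difference.

On these data alone, whether 3,5-dichlorophenyl would stand with compound 4 remains open. So does where plain phenyl would fall among these four compounds.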